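The compounds below may be only part of what the source reports. "The series", "measured", "known", "first", "only" and "open" are said of these compounds alone.

Going by the values given here, in a physicochemical assay for lipophilicity (on this read-out lower numbers stand for lower lipophilicity and higher numbers for higher lipophilicity), compound 1 `Cc1ccccc1C1=NC(c2ccccc2)CO1` gives 3.68 and stands as the higher of the two compounds measured so far. Compound 2 `O=[N+]([O-])c1ccccc1-c1ncco1` gives 1.27 in this assay and sits lower, with a gap beyond the usual scatter of repeated measurements. Among the compounds with values here, these two compounds differ in more than one place, so their gap offers no single-change step to carry forward.

The next compound for measurement is compound 3 `c1ccc(Oc2ccccc2C2=NC(c3ccccc3)CO2)cc1`, which keeps the core of compound 1. The change phenoxy in place of methyl on an aromatic carbon puts phenoxy in place of methyl on an aromatic carbon, ortho to a large group. Within the data shown here, no measured pair shows this change, so the expectation rests on the structural difference alone. The entering group brings more carbon and an additional aromatic ring, and an upward step beyond the scatter is expected. The expected size is a number 1.32 log units higher from compound 1 to compound 3 (beyond the scatter) in this assay as a working estimate. For compound 3 the estimated value is 5 with an expected range from 4.4 to 5.6 on this scale.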

Compound 3, partition coefficient: 5.61
Compound 3: the middle estimate sits 0.61 log units below what was measured; the whole stated range lies below it.
By their numbers in this assay, from the lowest: compound 2; then compound 1; then compound 3.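

Phenoxy in place of methyl on an aromatic carbon, ortho to a large group, gives the first single-change step in the series: in this assay the change reads as a number 1.93 log units higher from compound 1 to compound 3 (beyond the scatter) and counts as large. This position can therefore move the read-out a long way through one substitution, with the entering group bringing one six-membered aromatic ring of carbon only and one hydrogen-bond acceptor, and the presence of that acceptor does not stop the number from going up. No separate measurement in hand bears on what lies behind the size of this step.

With a single step at this position, the share of the oxygen link and the share of the added ring in the change remain unresolved, and a methoxy group or a phenyl group at the same place would pull those two parts apart in this assay. Going by these compounds alone, also open is how far the number would fall at this position with an amine or a carboxylic acid in place of methyl, as the step so far covers only an entering group without charge.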